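A Chloro for Fluoro Swap on Compound 3

The source may report more compounds than this note shows. Statements on the series, on what has been measured and on what is new or still open speak of the compounds shown alone.

In a functional assay on MCF7 cells (Homo sapiens) for cytotoxicity, read by WST assay, with a stated time of 72 h (a higher number here means a weaker inhibitor, a lower number a stronger inhibitor), compound 1 `Cc1cccc2c1NC(=O)C2(c1ccc(O)cc1)C1CCCCCC1` reports only a limit, > 1000 nM. Compound 2 `Cc1ccc2c(c1C)NC(=O)C2(c1ccc(O)cc1)C1CCCCCC1` gives 19 nM, and compound 3 `Cc1c(F)ccc2c1NC(=O)C2(c1ccc(O)cc1)C1CCCCCC1` gives 20 nM. These two values match within the scatter, with a 1.1-fold higher number from compound 2 to compound 3 (0.02 log units; within the scatter). Both compounds stand far from compound 1, with an at least 52-fold lower number from compound 1 to compound 2 (1.72 log units; beyond the scatter) and an at least 50-fold lower number from compound 1 to compound 3 (1.69 log units; beyond the scatter).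

Compound 4 `Cc1c(Cl)ccc2c1NC(=O)C2(c1ccc(O)cc1)C1CCCCCC1` differs from compound 3 by chloro in place of fluoro on an aromatic carbon. The large steps replaced hydrogen, so they bear on this swap less directly. The closest guide is the exchange of methyl and fluoro between compound 2 and compound 3, a 1.1-fold higher number from compound 2 to compound 3 (0.02 log units; within the scatter). The expected change is therefore none beyond the scatter, no change at the digits printed from compound 3 to compound 4 (within the scatter). Compound 4 is estimated at 20 nM, within an expected range of 8 nM to 50 nM.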

Compound 4, half-maximal inhibitory concentration: 51 nM
For compound 4 the middle estimate is 2.6-fold (0.41 log units) below the measured one; the measured number lies above the stated range.
By their numbers in this assay, from the lowest: compounds 2 and 3 (each within the scatter of the next); then compound 4. At a limit, above all of these: compound 1.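

Chloro sets this position apart in a way the earlier compounds did not: fluoro and methyl there had matched within the scatter, whereas chloro gives a 2.6-fold higher number from compound 3 to compound 4 (0.41 log units; beyond the scatter) and a 2.7-fold higher number from compound 2 to compound 4 (0.43 log units; beyond the scatter). Even so, chloro stays well clear of hydrogen at this place, with an at least 19-fold lower number from compound 1 to compound 4 (1.29 log units; beyond the scatter). That last step rests on compound 1, whose entry is a limit and not a number: the limit of > 1000 nM in this assay, at which 1 of the 4 values shown sits.

On these data alone, whether bromo, methoxy or an amine at this position would sit with fluoro and methyl or with chloro remains open.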